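Swapping the Amide Tail for a Tetrazole Ring

This account rests on a few compounds, and the source may have more. Where it says the series, first, only, none or still open, it means among the compounds named here.

Compound 1, `CCc1cc(C(C)=O)c(O)cc1OCCCC(C)(C)C#N`, gives 85% in an assay on isolated protein for inhibition of leukotriene B4 receptor 1 (Homo sapiens), tested at 10 uM; on this read-out higher numbers stand for more inhibition at the one concentration tested (going by the name of the read-out) and lower numbers for less inhibition.
Compound 2, `CCc1cc(C(C)=O)c(O)cc1OCCCCCCC(C)(C)C#N`, gives 65%.
Compound 3, `CCc1cc(C(C)=O)c(O)cc1OCCCCCCC(=O)N(C)C`, gives 100%.

Compound 3 stands highest of the three: the step of a number 15 percentage points higher from compound 1 to compound 3 (beyond the scatter) and the step of a number 35 percentage points higher from compound 2 to compound 3 (beyond the scatter) both lie beyond the scatter, so the chain ending in a dimethylcarbamoyl group is the best of the tails measured so far. The unmeasured compound 4, `CCc1cc(C(C)=O)c(O)cc1OCCCCc1nnn[nH]1`, differs from compound 3 in one place: 1H-tetrazol-5-yl in place of 2-(dimethylcarbamoyl)ethyl on a saturated chain carbon, four bonds along the chain from an oxygen on an aromatic ring. Going by the values given here, no measured step replaces this amide tail with an aromatic ring, so the only guide is that compound 3 owes its lead to that tail. Because a number 35 percentage points higher from compound 2 to compound 3 (beyond the scatter) was large when the dimethylcarbamoyl group entered, losing it is expected to cost something, though a tetrazole is a very different group from the nitrile tails of compound 1 and compound 2. A modest drop, a number 25 percentage points lower from compound 3 to compound 4 (beyond the scatter), is expected. Compound 4 is estimated at 75%, within 50% to 95%.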

Compound 4, a percentage reported as inhibition, at one concentration (the size of the read-out at that concentration, not a potency): 49%
Beside the measured number, compound 4's estimate is 26 percentage points above it, outside the stated range (below it).
By their numbers in this assay, from the lowest: compound 4; then compound 2; then compound 1; then compound 3.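

In this assay the change to 1H-tetrazol-5-yl is a number 51 percentage points lower from compound 3 to compound 4 (beyond the scatter) and so is a large loss, which shows that this ring does not stand in for the 2-(dimethylcarbamoyl)ethyl tail at this place on the chain. The ring also falls short of both nitrile tails, being a number 16 percentage points lower from compound 2 to compound 4 (beyond the scatter) and a number 36 percentage points lower from compound 1 to compound 4 (beyond the scatter) as well, which leaves compound 4 lowest of the four and shows that changing the tail can lower the number further than either nitrile tail does. Nothing measured here explains this drop.

Compound 4 also ends its tail closer to the shared core than compound 3 does, so the effect of the ring cannot be separated from that of the shorter reach. A tetrazole on a longer chain, or a carboxylic acid at the same place, would help to tell the two apart.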